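The compounds below may be only part of what the source reports. "The series", "measured", "known", "first", "only" and "open" are said of these compounds alone.

Of the compounds shown here, three have been measured in an assay on HEK293 cells for displacement of a labelled ligand from Melanocortin receptor 4 (Homo sapiens); on this read-out higher numbers stand for weaker inhibition and lower numbers for stronger inhibition. Compound 1 `CC(C)C[C@H](N)c1cc(C(F)(F)F)ccc1N1CCN(C(=O)CCc2cn(C)c3ccccc23)CC1` gives 3000 nM. Compound 2 `CCC(C)[C@H](NCc1ccccc1F)c1cc(C(F)(F)F)ccc1N1CCN(C(=O)CCc2ccc(Cl)cc2Cl)CC1` reaches only the limit of > 10000 nM, which is a limit of the assay and not a number (the limit of > 10000 nM in this assay, at which 1 of the 3 values shown sits). Compound 3 `CCC(C)[C@H](NCCN)c1cc(C(F)(F)F)ccc1N1CCN(C(=O)CCc2ccc(Cl)cc2Cl)CC1` gives 56 nM, the lowest number among the measured compounds, and the number of compound 1 stands clearly higher. For the measured compounds named here, the only measured step between two compounds that differ in a single place is an at least 170-fold lower number from compound 2 to compound 3 (2.25 log units; beyond the scatter): the arrival of the short amine-bearing chain went together with a large gain.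

Compound 4 `CCN[C@@H](CC(C)C)c1cc(C(F)(F)F)ccc1N1CCN(C(=O)CCc2ccc(Cl)cc2Cl)CC1` differs from compound 3 by 1-(ethylamino)-3-methylbutyl in place of 1-((2-aminoethyl)amino)-2-methylbutyl on an aromatic carbon. The group that leaves carries the 2-aminoethyl chain whose arrival marked that large step; the group that enters has no such chain, only an ethyl on the nitrogen. Compound 4 is therefore expected to give a higher number, around 1500 nM. The range expected for compound 4 runs from 300 nM to 8000 nM. The expected step is a 27-fold higher number from compound 3 to compound 4 (1.43 log units; beyond the scatter).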

Compound 4, inhibition constant: 170 nM
For compound 4 the middle estimate is 8.8-fold (0.95 log units) above the measured one, outside the stated range (below it).
By their numbers in this assay, from the lowest: compound 3; then compound 4; then compound 1. At a limit, above all of these: compound 2.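

The change from compound 3 to compound 4 gives a 3.0-fold higher number from compound 3 to compound 4 (0.48 log units; beyond the scatter) in this assay, so the terminal amine of the 2-aminoethyl chain is not essential for a number of this order, although its removal still leaves a step beyond the scatter. The change is also not a clean removal of that amine, since the methyl branch differs too, with 2-methylbutyl in compound 3 and 3-methylbutyl in compound 4. Nothing measured here gives a reason for the size of this step.

From the compounds shown here alone, how much of the step belongs to the amine and how much to the branch stays open. Also open, going by these compounds, is where a 2-hydroxyethyl or a longer 3-aminopropyl chain on the same nitrogen would fall relative to compound 3 and compound 4.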